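Swapping a hydroxyphenyl amide for a fluorophenyl amide

This account rests on a few compounds, and the source may have more. Where it says the series, first, only, none or still open, it means among the compounds named here.

Compound 3, `COc1ccc(-c2cnc(NC(=O)c3cccc(O)c3)n2C)cc1`, was tested in a toxicity assay on THP-1 cells (Homo sapiens) for inhibition; a higher number here means that more compound is tolerated, a lower number that less compound is tolerated. In this assay compound 3 gives > 100000 nM, which is a limit of the assay and not a number. Two related compounds stand beside it. Compound 1, `Cn1c(-c2ccccc2F)cnc1NC(=O)c1ccc(F)cc1`, gives in this assay > 100000 nM, again a limit. Compound 2, `Cn1c(-c2ccccc2Cl)cnc1NC(=O)c1ccc(F)cc1`, gives in this assay > 50000 nM, also a limit. Among the compounds with values here, the only measured step, a step that the two limits leave unreadable from compound 1 to compound 2, has both ends at a limit and so cannot be read. The whole picture is thus the limit of > 100000 nM in this assay, at which 2 of the 3 values shown sit, together with the limit of > 50000 nM in this assay, at which 1 of the 3 values shown sits; not one compound shown has a measured number.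

Compound 4, `COc1ccc(-c2cnc(NC(=O)c3ccc(F)cc3)n2C)cc1`, differs from compound 3 in one place: 4-fluorophenyl in place of 3-hydroxyphenyl on a carbonyl carbon. Within the data shown here, no measured step bears on this change, and the three limits give no size to work from. Compound 4 is therefore expected to sit at a limit as well, estimated at 100000 nM, with a range from 50000 nM to 200000 nM. The step so expected, a number no higher from compound 3 to compound 4 (the limit leaves the size open), is estimated as nothing beyond the scatter.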

Compound 4, half-maximal cytotoxic concentration: >= 50000 nM
Compound 4: no number, only a limit; the forecaster's own chance of this, stated with the estimate: 85%; the middle value does not contradict the limit.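

Compound 4 also gives only a limit and not a number, and so the steps that link it to compound 1, compound 2 and compound 3 cannot be read. The compounds shown leave open whether any of these changes alters tolerance in this assay, and by how much.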